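Swapping the thiourea tail for a dichlorophenyl urea

The source may hold more compounds than are shown below. What is called first, only, known or untested is meant among the compounds shown, and "the series" means these compounds.

Measured so far:
- Compound 1 `COc1ccc(Oc2ccc([N+](=O)[O-])cc2-c2ccsc2S(=O)(=O)N2CCN(C(=O)Nc3ccc([N+](=O)[O-])cc3)CC2)cc1OC`, in a functional assay on HL-60 cells (Homo sapiens) for inhibition, read by CCK-8 assay, with a stated time of 48 h (on this read-out lower numbers stand for stronger inhibition and higher numbers for weaker inhibition), reaches only a limit of the assay: > 50000 nM (the limit of > 50000 nM in this assay, at which 1 of the 3 values shown sits).
- Compound 2 `Cc1ccc(-c2ccsc2S(=O)(=O)NCCNC(=S)Nc2ccc([N+](=O)[O-])cc2)c(Oc2ccc(O)c(O)c2)c1` gives 2900 nM in this assay.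
- Compound 3 `O=S(=O)(NCCNC(=S)Nc1cc(C(F)(F)F)cc(C(F)(F)F)c1)c1ccc(-c2ccccc2Oc2ccc(O)c(O)c2)s1` gives 18300 nM in this assay.

Among these, compound 2 holds the lowest of the two actual numbers; compound 3 sits higher by a margin beyond the usual scatter of repeated measurements, and compound 1 contributes only a limit rather than a number. Going by the values given here, no two of the measured compounds differ in a single place, so no measured step is available to lean on.

Compound 4 `Cc1ccc(-c2ccsc2S(=O)(=O)NCCNC(=O)Nc2cc(Cl)cc(Cl)c2)c(Oc2ccc(O)c(O)c2)c1` has not yet been measured. It is built from compound 2 by the change (a group of 11 heavy atoms (7 carbon, 1 nitrogen, 1 oxygen, 2 chlorine; one six-membered aromatic ring of carbon only) in place of a group of 12 heavy atoms (7 carbon, 2 nitrogen, 2 oxygen, 1 sulfur; one six-membered aromatic ring of carbon only), on an amine nitrogen). Among the compounds with values here, since nothing among the measured compounds shows what this particular exchange does, the expectation rests on compound 2 alone, with a wide margin in both directions. The step from compound 2 to compound 4 is expected to be small, most likely a modest loss, as in a 1.7-fold higher number from compound 2 to compound 4 (0.24 log units; within the scatter). Compound 4 is therefore estimated to give about 5000 nM in this assay, with a plausible range from 1500 nM to 20000 nM.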

Compound 4, half-maximal inhibitory concentration: 3500 nM
Compound 4: middle estimate off by 1.4-fold (0.15 log units), on the high side; low and high end bracket the measured number.
By their numbers in this assay, from the lowest: compounds 2 and 4 (each within the scatter of the next); then compound 3. At a limit, above all of these: compound 1.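

In this assay, going by these compounds alone, exchanging the group on the amine nitrogen gives a 1.2-fold higher number from compound 2 to compound 4 (0.08 log units; within the scatter), the first step that can be read directly. It shows that, on this shared core, the (3,5-dichlorophenyl)carbamoyl group can stand in for the thiourea tail bearing a nitrophenyl ring with no difference that can be told from the scatter, so neither the sulfur of the thiourea nor the nitro group is needed for activity at this level once the urea and the two chlorines are present together. The step changes the linking unit and the ring substituents at once, so it gives no separate reading of either change, and the two may have no effect or may have opposing effects that happen to cancel.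

Still open, from the compounds shown here alone, is what each part does alone, which a urea keeping the nitrophenyl ring or a thiourea carrying the dichlorophenyl ring would show, and whether a plain phenyl ring, an amine or a carboxylic acid on that ring would be tolerated as well. Nothing measured here explains why the two groups give such similar values.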